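A Chlorothiazole Sulfonamide Tested Against Three Ceilings

This account rests on a few compounds, and the source may have more. Where it says the series, first, only, none or still open, it means among the compounds named here.

The account follows three sulfonamides screened in an ADME assay on HCT-116 cells (Homo sapiens) for cytotoxicity, read by CellTiter-Glo, with a stated time of 72 h; on this read-out lower numbers stand for stronger inhibition and higher numbers for weaker inhibition. Compound 1 `Cc1cc(C)c(S(=O)(=O)N2CCN(C3CN4CCC3CC4)CC2)c(C)c1` is reported only as a limit of this assay, at > 5000 nM. Compound 3 `COc1ccccc1-c1ccc(S(=O)(=O)N2CCC(N3CCC(C)CC3)CC2)cc1` likewise stops at a limit, > 5000 nM. Compound 2 `Cc1noc(C)c1S(=O)(=O)N1CCC(N2CCC(C)CC2)CC1` is read as a limit as well, here > 10000 nM. None of the three therefore stands at a measured number: two share (the limit of > 5000 nM in this assay, at which 2 of the 3 values shown sit), while compound 2 alone sits at the limit of > 10000 nM in this assay, at which 1 of the 3 values shown sits. Among the measured compounds shown here, with only limits in hand, no step between measured compounds can be stated, and compound 2 stands simply at the far edge of what this assay reports.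

Compound 4 `CC1CCN(C2CCN(S(=O)(=O)c3cnc(Cl)s3)CC2)CC1` has not yet been tested. It differs from compound 2 in one place: 2-chloro-1,3-thiazol-5-yl in place of 3,5-dimethyl-1,2-oxazol-4-yl on a sulfonyl sulfur. The sulfonyl sulfur and the sulfonamide nitrogen in a ring are untouched. For the measured compounds named here, because compound 2 sits at the limit of > 10000 nM in this assay, at which 1 of the 3 values shown sits, and compounds 1 and 3 at the limit of > 5000 nM in this assay, at which 2 of the 3 values shown sit, no measured step supplies a direction, and the account expects no movement beyond the usual scatter in this assay. Compound 4 is accordingly estimated at 12000 nM in this assay, within 5000 nM to 30000 nM. The expected step that the limit leaves unreadable from compound 2 to compound 4 is essentially none. Whether the read-out again returns only a limit is what the measurement will tell.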

Compound 4, half-maximal inhibitory concentration: > 10000 nM
Compound 4 ended at the assay's limit; the forecaster's own chance of this, stated with the estimate: 75%; the middle value does not contradict the limit.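

In this assay compound 4 gives > 10000 nM as a limit of the read-out. Among the compounds shown here, compound 2 also stands at a limit, so no step from compound 2 to compound 4 can be read. The compounds shown leave open whether 2-chloro-1,3-thiazol-5-yl and 3,5-dimethyl-1,2-oxazol-4-yl differ at all in this assay once actual numbers are available.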